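The source may hold more compounds than are shown below. What is called first, only, known or untested is meant among the compounds shown, and "the series" means these compounds.

Working notes on the series, read in a physicochemical assay for solubility, read by HPLC, in phosphate buffer, measured as kinetic solubility, at pH 7.4; a lower number here means a less soluble compound, a higher number a more soluble compound. Compound 1 (`CCC(=O)c1cc(-c2ccc(Cl)cc2)n(-c2cccc(S(N)(=O)=O)c2)c1C`) gives 200 nM, compound 2 (`CCC(=O)c1cc(-c2ccccc2Cl)n(-c2ccc(S(N)(=O)=O)cc2)c1C`) gives 38200 nM and compound 3 (`CCC(=O)c1cc(-c2ccc(S(N)(=O)=O)cc2)nn1-c1ccc(Cl)cc1`) gives 49600 nM. Compound 3 stands level with compound 2, the two lying within the scatter of each other, and beyond the scatter above compound 1.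

Compound 4 (`CCC(=O)c1cc(-c2ccc(S(N)(=O)=O)cc2)nn1-c1cccc(Cl)c1`) carries 3-chlorophenyl in place of 4-chlorophenyl on an aromatic nitrogen. The two compounds have the same atoms, joined differently.

Among the measured compounds shown here, no measured pair differs in one place, so the data give no direct size for this change. A small downward move in this assay is expected, possibly none beyond the scatter. The expected size is a 1.6-fold lower number from compound 3 to compound 4 (0.19 log units; within the scatter). The range stays wide on the low side because compound 1 reads 200 nM, although that compound differs from compound 3 in more than one place. For compound 4 the estimated value is 32000 nM, with an expected range of 11000 nM to 60000 nM.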

Compound 4, solubility: 700 nM
Compound 4: the middle estimate sits 46-fold (1.66 log units) above what was measured; the whole stated range lies above it.
By their numbers in this assay, from the lowest: compound 1; then compound 4; then compounds 2 and 3 (each within the scatter of the next).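

In this assay, among the compounds shown here, 3-chlorophenyl in place of 4-chlorophenyl on the aromatic nitrogen gives a 71-fold lower number from compound 3 to compound 4 (1.85 log units; beyond the scatter), the only step that differs in one place. The step is large and beyond the scatter, although the group that leaves and the group that enters have the same counts of heavy atoms, donors and acceptors, so at this position the attachment of the chlorophenyl alone can separate two compounds widely. Nothing measured here accounts for the step.

Only these two chlorophenyl groups are shown at this position, so it stays open whether a plain phenyl, or a phenyl carrying an amine or a carboxylic acid, would read nearer compound 3 or nearer compound 4. Going by these compounds, compounds 1 and 2 differ in more than one place, so whether the same exchange matters elsewhere on the core also stays open.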